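The source may hold more compounds than are shown below. What is called first, only, known or untested is meant among the compounds shown, and "the series" means these compounds.

Measured compounds in an assay on cells for inhibition of Amine oxidase [flavin-containing] A (Homo sapiens), read by fluorescence and Amplex Red, with a stated time of 15 min; a higher number here means a weaker inhibitor, a lower number a stronger inhibitor:
Compound 1 `Cc1cccc2cc(-c3ccc(Br)cc3)oc12`: compound 1 gives 100000 nM
Compound 2 `Cc1cccc2cc(-c3ccccc3Br)oc12`: compound 2 gives 100000 nM
Compound 3 `Brc1ccccc1-c1cc2ccccc2o1`: compound 3 gives 8120 nM

Compound 2 stands level with compound 1 at the digits reported, and together the two give the highest numbers of the three in this assay. Among the measured compounds shown here, its one neighbour that differs in a single place is compound 3, reached by a 12-fold lower number from compound 2 to compound 3 (1.09 log units; beyond the scatter), a large step, through hydrogen in place of methyl on an aromatic carbon of the shared core.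

Compound 4 `Cc1cccc2cc(-c3ccccc3)oc12` is not yet measured. It arises from compound 2 by hydrogen in place of bromo on an aromatic carbon, on an aromatic carbon of a six-membered aromatic ring of carbon only, ortho to a large group. For the measured compounds named here, no measured step covers removal of the bromo; the only step known, from compound 2 to compound 3, concerns the methyl, and compound 1 and compound 2 show merely that shifting the bromo changes nothing at the digits reported while the methyl is present. With the methyl kept, the expectation for compound 4 is therefore a weak inhibitor, estimated at 50000 nM with a range of 10000 nM to 100000 nM. That estimate corresponds to the expected step of a 2.0-fold lower number from compound 2 to compound 4 (0.30 log units; within the scatter).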

Compound 4, half-maximal inhibitory concentration: 100000 nM
For compound 4 the middle estimate is 2.0-fold (0.30 log units) below the measured one; low and high end bracket the measured number.
By their numbers in this assay, from the lowest: compound 3; then compounds 1, 2 and 4 (each within the scatter of the next).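

In this assay, hydrogen in place of bromo on the aromatic carbon ortho to a large group gives no change at the digits printed from compound 2 to compound 4 (within the scatter) and, for the other bromo compound, no change at the digits printed from compound 1 to compound 4 (within the scatter) with the methyl kept in both cases. The earlier compounds had shown only that shifting the bromo left the reading unchanged; these steps add that taking it away altogether does so too, leaving the removal of the methyl, a 12-fold lower number from compound 2 to compound 3 (1.09 log units; beyond the scatter) as the only step beyond the scatter among these compounds. Nothing given here accounts for the absence of any change on removing the bromo.

Among the compounds shown here, what the bromo does when the methyl is absent stays open, since the one compound without the methyl, compound 3, still carries it and has no neighbour without it. Also open, on these data alone, is whether another group at this place, such as an amine, a methoxy or a carboxylic acid, would move the number in this assay while the methyl is present.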